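A few compounds are considered here, and "the series" means these few. Any claim that something is new, unique, unknown or untested is made for them only; others in the source may bear on it.

In a functional assay on A549 cells (Homo sapiens) for inhibition, read by CCK-8 assay, with a stated time of 72 h, tested at 2 uM (a lower number here means less inhibition of growth, a higher number more inhibition of growth at the concentration tested), compound 1 `COc1ccc(SCc2ccc(C(=O)Nc3ccccc3N)cc2)cc1` gives 45.7%. This sits within the usual scatter of the two other measured compounds, compound 2 `Nc1ccccc1NC(=O)/C=C/c1ccc(CSc2ccc(C(F)(F)F)cn2)cc1` at 51.7% and compound 3 `Nc1ccccc1NC(=O)/C=C/c1ccc(CSc2ccc(F)cc2)cc1` at 51.2%. Compound 4 `Nc1ccccc1NC(=O)c1ccc(CSc2ccc(Br)cc2)cc1` has bromo in place of methoxy on an aromatic carbon of the core of compound 1, para to a large group (bromo in place of methoxy on an aromatic carbon). Within the data shown here, no measured step makes this exact swap. The closest evidence is another aromatic change on a sulfur, a number 0.5 percentage points lower from compound 2 to compound 3 (within the scatter), and that step stays within the scatter. No step beyond the scatter is therefore expected in this assay, and no direction can be favoured. The expected step is a number 2.3 percentage points higher from compound 1 to compound 4 (within the scatter). The estimate for compound 4 is 48%, with an expected range from 36% to 60%.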

Compound 4, percent growth inhibition at one concentration: 33.2%
Estimate against measurement, compound 4: 14.8 percentage points above; the whole stated range lies above it.
By their numbers in this assay, from the lowest: compound 4; then compounds 1, 3 and 2 (each within the scatter of the next).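

Among these compounds, on an aromatic carbon para to a large group, the change from 4-methoxyphenyl to 4-bromophenyl gives the first step beyond the scatter in this assay (a number 12.5 percentage points lower from compound 1 to compound 4 (beyond the scatter)). The group at this place can therefore matter, which the earlier aromatic change on sulfur did not show (a number 0.5 percentage points lower from compound 2 to compound 3 (within the scatter)). No available evidence explains the loss.

Going by these compounds, one pair sets no trend, so it remains open how other groups at this place would compare. An amine or a carboxylic acid on the same carbon would test this further.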